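A few compounds are considered here, and "the series" means these few. Any claim that something is new, unique, unknown or untested is made for them only; others in the source may bear on it.

Compound 1 `COc1cc(/C=N/Nc2nc(-c3cc(C(F)(F)F)cc(C(F)(F)F)c3)cs2)cc(Br)c1OC`: in a functional assay on U-87MG ATCC cells for inhibition, with U-87 MG (Homo sapiens) as the target, read by MTT assay, with a stated time of 48 h (a higher number here means a weaker inhibitor, a lower number a stronger inhibitor), compound 1 sits at the assay limit, > 100000 nM.
Compound 2 `COc1cc(/C=N/Nc2nc(-c3ccc(F)c(F)c3)cs2)cc(Br)c1OC`: compound 2 gives 26300 nM.
Compound 3 `COc1cc(/C=N/Nc2nc(-c3ccc(F)c(F)c3)cs2)c(Br)c(Br)c1OC`: compound 3 gives 19600 nM.

Going by the values given here, compound 3 holds the lower of the two numbers, but the only measured step, a 1.3-fold lower number from compound 2 to compound 3 (0.13 log units; within the scatter), lies within the scatter, so compound 2 and compound 3 cannot be separated. Compound 4 `COc1cc(/C=N/Nc2nc(-c3cccc(Br)c3)cs2)c(Br)c(Br)c1OC` differs from compound 3 by 3-bromophenyl in place of 3,4-difluorophenyl on an aromatic carbon. Among the compounds with values here, no measured step changes the group at this place between two numbers: compound 1 carries a different group there and sits at a limit (the limit of > 100000 nM in this assay, at which 1 of the 3 values shown sits), which gives no size. Within the data shown here, the one measured step concerns a bromo substituent elsewhere and was small. The expectation for compound 4 is therefore a step of a 1.0-fold higher number from compound 3 to compound 4 (0.01 log units; within the scatter), nothing beyond the scatter, with an estimate of 20000 nM in a range from 7000 nM to 60000 nM.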

Compound 4, half-maximal inhibitory concentration: 27600 nM
Beside the measured number, compound 4's estimate is 1.4-fold (0.14 log units) below it; low and high end bracket the measured number.
By their numbers in this assay, from the lowest: compounds 3, 2 and 4 (each within the scatter of the next). At a limit, above all of these: compound 1.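

Going by these compounds alone, the first readable step at this place, on the aromatic carbon next to the ring nitrogen, replaces 3,4-difluorophenyl with 3-bromophenyl in this assay: a 1.4-fold higher number from compound 3 to compound 4 (0.15 log units; within the scatter). This exchange of halogenated phenyl groups therefore gives no separation between compound 3 and compound 4. Nothing in the data shown bears on why these two groups read alike.

Still open, as far as these compounds go, is whether any group at this place gives a sized step beyond the scatter. From the compounds shown here alone, an aminophenyl or a carboxyphenyl group here would test that, and the effect of either remains unknown.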